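Trimming the chain: cytotoxicity estimate for compound 4

The source may hold more compounds than are shown below. What is called first, only, known or untested is meant among the compounds shown, and "the series" means these compounds.

Measured so far in an ADME assay on MT4 cells (Homo sapiens) for cytotoxicity, read by MTT assay; on this read-out higher numbers stand for lower toxicity in this test and lower numbers for higher toxicity in this test:
compound 1 `Cc1cc(C)cc(S(=O)(=O)c2c(C(=O)NC(C)C(=O)NCc3ccccc3F)[nH]c3ccc(Cl)cc23)c1` gives 23300 nM
compound 2 `Cc1cc(C)cc(S(=O)(=O)c2c(C(=O)NCC(=O)NC(C)c3ccccc3)[nH]c3ccc(Cl)cc23)c1` gives 29400 nM
compound 3 `Cc1cc(C)cc(S(=O)(=O)c2c(C(=O)NC(C)C(=O)NC(C)c3ccccc3F)[nH]c3ccc(Cl)cc23)c1` gives 15200 nM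

Compound 1 stands second highest of these three numbers; compound 2 is nearest, and the gap to compound 3 is a 1.5-fold lower number from compound 1 to compound 3 (0.19 log units; within the scatter), so all three sit within the scatter of one another. Compound 4 `Cc1cc(C)cc(S(=O)(=O)c2c(C(=O)NC(C)c3cc(F)cc(F)c3)[nH]c3ccc(Cl)cc23)c1` differs from compound 1 by 3,5-difluorophenyl in place of (2-fluorobenzyl)carbamoyl on a saturated chain carbon bound to an amide-type nitrogen and a saturated chain carbon. For the measured compounds named here, the only measured step, from compound 1 to compound 3, is a different change, a methyl in place of hydrogen, and says nothing about removing the (2-fluorobenzyl)carbamoyl unit. Going by the values given here, with no step bearing on this change and all measured values close together, no shift beyond the scatter is expected in this assay; the expected step is a 1.1-fold lower number from compound 1 to compound 4 (0.02 log units; within the scatter). Compound 4 is therefore estimated at 22000 nM, between 9000 nM and 50000 nM.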

Compound 4, half-maximal cytotoxic concentration: > 49700 nM
Compound 4 gave a limit, no number; the forecaster's own chance of this, stated with the estimate: 15%; at least 2.2-fold (0.35 log units) between middle value and limit.
By their numbers in this assay, from the lowest: compounds 3, 1 and 2 (each within the scatter of the next). At a limit, above all of these: compound 4.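

Compound 4 gave a limit and not a number: the limit of > 49700 nM in this assay, at which 1 of the 4 values shown sits. In this assay, 3,5-difluorophenyl in place of the carbamoyl units on this saturated chain carbon gives the first shift beyond the scatter towards lower toxicity in this test, with an at least 2.1-fold higher number from compound 1 to compound 4 (0.32 log units; beyond the scatter) and an at least 3.2-fold higher number from compound 3 to compound 4 (0.51 log units; beyond the scatter). The different change seen in an at least 1.6-fold higher number from compound 2 to compound 4 (0.22 log units; that floor lies within the scatter) settles nothing alone.

Going by these compounds, how far compound 4 lies past its limit stays open, as does whether losing the carbamoyl unit or gaining the fluorines matters. On these data alone, what an amine or a carboxylic acid would give at this place is also open.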